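The source may hold more compounds than are shown below. What is called first, only, known or untested is meant among the compounds shown, and "the series" means these compounds.

Measured in a functional assay on PC-3 cells (Homo sapiens) for inhibition, read by sulforhodamine B assay, with a stated time of 72 h; on this read-out higher numbers stand for weaker inhibition and lower numbers for stronger inhibition:
- compound 1 `CC1CN(C(=O)c2c(N)sc(-c3ccc(Cl)cc3)c2-c2ccc(Cl)cc2)CCN1`: 7210 nM
- compound 2 `CC1CCN(C(=O)c2c(N)sc(-c3ccc(Cl)cc3)c2-c2ccc(Cl)cc2)CC1`: 5750 nM

Among the compounds with values here, compound 2 gives 5750 nM, which lies within the usual scatter of the only other measured value. Compound 3 `Nc1sc(-c2ccc(Cl)cc2)c(-c2ccc(Cl)cc2)c1C(=O)NC1CCC1` differs from it on a carbonyl carbon: cyclobutylamino in place of 4-methylpiperidin-1-yl on a carbonyl carbon. Within the data shown here, the one measured step at this place, a 1.3-fold lower number from compound 1 to compound 2 (0.10 log units; within the scatter), stayed within the scatter. On that evidence, no step beyond the scatter is expected in this assay. Among the measured compounds shown here, no measured compound carries cyclobutylamino, however, and the range is kept wide. Compound 3 is estimated at 6000 nM, with an expected range of 2500 nM to 15000 nM. The expected change is a 1.0-fold higher number from compound 2 to compound 3 (0.02 log units; within the scatter).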

Compound 3, half-maximal inhibitory concentration: 24800 nM
Compound 3: the middle estimate sits 4.1-fold (0.62 log units) below what was measured, and the stated range ends below it.
By their numbers in this assay, from the lowest: compounds 2 and 1 (each within the scatter of the next); then compound 3.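

In this assay, this place on the carbonyl carbon is not indifferent to what it carries: the change to cyclobutylamino gives a 4.3-fold higher number from compound 2 to compound 3 (0.63 log units; beyond the scatter) and likewise a 3.4-fold higher number from compound 1 to compound 3 (0.54 log units; beyond the scatter) even though the two ring amines stayed within the scatter of each other. Nothing available here explains this weaker inhibition. The compounds shown leave open whether the smaller ring or the amide hydrogen matters more, and a cyclohexylamino group or an N-methylcyclobutylamino group would help separate the two.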